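The source may report more compounds than this note shows. Statements on the series, on what has been measured and on what is new or still open speak of the compounds shown alone.

Measured compounds and their numbers in an in vivo ADME assay on the whole organism (strain Sprague-Dawley) for metabolic stability, with Rattus norvegicus as the target; on this read-out higher numbers stand for a longer-lived compound and lower numbers for a shorter-lived compound:

compound 1, `CCCCCOC(=O)N1CCN(C(=O)[C@H](CCC(=O)O)NC(=O)c2cc(N3CCC(OCCO)CC3)nc(-c3ccccc3)n2)CC1`: 0.00833 h
compound 2, `CCCCCOC(=O)N1CCN(C(=O)[C@H](CCC(=O)O)NC(=O)c2cc(N3CCC(COC)CC3)nc(-c3ccccc3)n2)CC1`: 0.015 h
compound 3, `CCCCCOC(=O)N1CCN(C(=O)[C@H](CCC(=O)O)NC(=O)c2cc(N3CCC(C(=O)N4CCCC4)CC3)nc(-c3ccccc3)n2)CC1`: 0.0133 h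

All three numbers sit close together. Compound 3 lies with compound 2 and compound 1 inside the usual scatter on either side: a 1.1-fold lower number from compound 2 to compound 3 (0.05 log units; within the scatter) and a 1.6-fold higher number from compound 1 to compound 3 (0.20 log units; within the scatter). The third pairing behaves the same way: a 1.8-fold higher number from compound 1 to compound 2 (0.26 log units; within the scatter). Nothing among the three changes on the saturated ring carbon has moved this assay beyond its noise.

Compound 4, `CCCCCOC(=O)N1CCN(C(=O)[C@H](CCC(=O)O)NC(=O)c2cc(N3CCC(CNC)CC3)nc(-c3ccccc3)n2)CC1`, has not been measured. Against compound 3 the change is (methylamino)methyl in place of (pyrrolidin-1-yl)carbonyl on a saturated ring carbon. For the measured compounds named here, the steps that bear on it are those that replaced the same position: from compound 1 to compound 3 and from compound 2 to compound 3, both within the scatter, and from compound 1 to compound 2 likewise. A group with one hydrogen-bond donor enters where none stood before, but the three measured substituents at this position, one with a donor among them, gave no step beyond the scatter, so no step beyond the scatter is expected here either: the estimated step from compound 3 to compound 4 is a 1.0-fold lower number from compound 3 to compound 4 (0.01 log units; within the scatter).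

Compound 4 is therefore estimated at 0.013 h in this assay, with an expected range from 0.006 h to 0.03 h.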

Compound 4, half-life: 0.0117 h
Beside the measured number, compound 4's estimate is 1.1-fold (0.05 log units) above it; the measured number falls inside the stated range.
By their numbers in this assay, from the lowest: compounds 1, 4, 3 and 2 (each within the scatter of the next).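

Working notes on the saturated ring carbon, read in this assay: (methylamino)methyl, with 3 heavy atoms and no ring, replaces (pyrrolidin-1-yl)carbonyl, with 7 heavy atoms and a five-membered ring, and the step stays within the scatter (a 1.1-fold lower number from compound 3 to compound 4 (0.06 log units; within the scatter)), so on these two compounds neither the loss of that ring nor the drop in heavy atoms separates the half-lives. The closest exchange in the set, methylamino in place of methoxy on a saturated chain carbon bound to that ring carbon, also stays within the scatter (a 1.3-fold lower number from compound 2 to compound 4 (0.11 log units; within the scatter)), as does the exchange of 2-hydroxyethoxy for (methylamino)methyl (a 1.4-fold higher number from compound 1 to compound 4 (0.15 log units; within the scatter)), which extends the flat picture at this position to an amine alongside the ethers and the amide. No measurement is available that explains why these half-lives remain indistinguishable.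

Still open, from the compounds shown here alone, is whether a carboxylic acid, a dimethylamino group or a longer alkyl chain on this carbon would give a step beyond the scatter. The compounds shown also leave open how the half-life responds to a change anywhere outside this position, since the rest of the structure is the same in all four.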